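Isobutyl for Isopropyl on a Compound at the Assay Limit

This account rests on a few compounds, and the source may have more. Where it says the series, first, only, none or still open, it means among the compounds named here.

Compound 2 `CC(C)[C@H](NC(=O)[C@H](C)NC(=O)c1cn(CC(=O)NOCc2ccccc2)c2ccccc12)C(=O)O` was examined in a functional assay on RAW264.7 cells (Mus musculus) for inhibition, read by microscopy and resazurin assay, with a stated time of 72 h; a higher number here means a weaker inhibitor, a lower number a stronger inhibitor. In this assay compound 2 gives > 128000 nM, which is a limit of the assay and not a number. Compound 1 `C=CCONC(=O)Cn1cc(C(=O)N[C@@H](C)C(=O)N[C@@H](CC(C)C)C(=O)O)c2ccccc21` likewise gives > 128000 nM in this assay, again a limit. Both values sit together at the limit of > 128000 nM in this assay, at which 2 of the 2 values shown sit. Compound 3 `CC(C)C[C@H](NC(=O)[C@H](C)NC(=O)c1cn(CC(=O)NOCc2ccccc2)c2ccccc12)C(=O)O` has not yet been measured in this assay. It differs from compound 2 by isobutyl in place of isopropyl on a saturated chain carbon bound to an amide-type nitrogen and a carbonyl carbon. Among the compounds with values here, no step between measured compounds is available, and compound 1 already carries isobutyl at that place. The expected step from compound 2 to compound 3 is therefore a step that the limit leaves unreadable from compound 2 to compound 3, nothing beyond the scatter. Compound 3 is estimated to give 200000 nM in this assay, within 100000 nM to 600000 nM, most likely again reported only as a limit.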

Compound 3, half-maximal inhibitory concentration: > 128000 nM
Compound 3 ended at the assay's limit (the forecaster's own chance of this, stated with the estimate: 85%); the middle value is on the limit's open side.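

In this assay compound 3 gives > 128000 nM, a limit of the assay and not a number. The steps to compound 3 from compound 1 and compound 2 cannot be read. The compounds shown leave open whether isobutyl and isopropyl differ at that place in this assay.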